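The source may hold more compounds than are shown below. What is called first, only, known or untested is meant among the compounds shown, and "the series" means these compounds.

- compound 1 (`O=C(CN1CCN(C(=O)c2ccc(Cl)cc2)CC1)N1CCN(CCCc2c[nH]c3ccc(F)cc23)CC1`) : 125000 nM
- compound 2 (`COc1ccc2[nH]cc(CCCN3CCN(C(=O)CN4CCN(C(=O)c5ccc(Cl)cc5)CC4)CC3)c2c1`) : 159000 nM

Among the measured compounds shown here, both compounds have been measured in an ADME assay on SH-SY5Y cells (Homo sapiens) for cytotoxicity, read by MTT assay, with a stated time of 72 h (on this read-out higher numbers stand for weaker inhibition and lower numbers for stronger inhibition), and their values lie within the scatter of each other, so compound 2 stands level with compound 1 on the numbers available. The next compound to be measured is compound 3 (`COc1ccc2[nH]cc(CCCN3CCN(C(=O)CN4CCN(C(=O)c5cccc(Br)c5)CC4)CC3)c2c1`). It differs from compound 2 as follows: 3-bromophenyl in place of 4-chlorophenyl on a carbonyl carbon. In words, this is 3-bromophenyl in place of 4-chlorophenyl on a carbonyl carbon.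

For the measured compounds named here, only one measured step is available, a 1.3-fold higher number from compound 1 to compound 2 (0.10 log units; within the scatter), and it is methoxy in place of fluoro on an aromatic carbon. That is a different exchange from this one, so it bears on the question only indirectly. Going by the values given here, no measured compound shows what an exchange on this carbonyl carbon does in this assay. With so little to go on, no step beyond the scatter is expected. The expected step is a 1.2-fold lower number from compound 2 to compound 3 (0.09 log units; within the scatter). For compound 3 the estimated value is 130000 nM, with an expected range from 65000 nM to 240000 nM.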

Compound 3, half-maximal inhibitory concentration: 105000 nM
Compound 3: the middle estimate sits 1.2-fold (0.09 log units) above what was measured; the measured number falls inside the stated range.
By their numbers in this assay, from the lowest: compounds 3, 1 and 2 (each within the scatter of the next).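

In this assay, the first exchange read on a carbonyl carbon whose other neighbours are an amide-type nitrogen in a ring gives a 1.5-fold lower number from compound 2 to compound 3 (0.18 log units; within the scatter), so compound 3 stands level with compound 2 on these numbers. The two groups count alike, each with 7 heavy atoms, one six-membered aromatic ring of carbon only and no net charge, but the kind of halogen and its place on the ring change together, so this single step cannot separate the two changes. Nothing available explains the outcome of this exchange.

The compounds shown leave open whether 4-bromophenyl or 3-chlorophenyl, each of which would separate the two changes, would also stay within the scatter of compound 2, and whether 3-bromophenyl would give a similar reading alongside the fluoro group of compound 1 in place of the methoxy group. They also leave open what a phenyl ring carrying an amine or a carboxylic acid in place of the halogen would give at this carbonyl carbon.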